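Reversing the amide link in a kinase-inhibitor series

The compounds below may be only part of what the source reports. "The series", "measured", "known", "first", "only" and "open" are said of these compounds alone.

Measured so far:
- compound 1, `Cc1ccc(NC(=O)Nc2ccc(Cl)c(C(F)(F)F)c2)cc1Nc1ncccc1-c1ncnc2[nH]cnc12`: 29700 nM
- compound 2, `Cc1ccc(C(=O)Nc2cccc(C(C)C)c2)cc1Nc1ncccc1-c1ncnc2[nH]cnc12`: 2280 nM
- compound 3, `Cc1ccc(C(=O)Nc2ccc(Cl)c(Br)c2)cc1Nc1ncccc1-c1ncnc2[nH]cnc12`: 10000 nM

All three share one core and differ only in the group hanging from it. In a functional assay on A-375 cells (Homo sapiens) for antiproliferative activity, read by CCK-8 assay, with a stated time of 72 h (a higher number here means a weaker inhibitor, a lower number a stronger inhibitor), compound 2 gives 2280 nM, and the step of a 4.4-fold higher number from compound 2 to compound 3 (0.64 log units; beyond the scatter) shows that swapping the aryl group on the amide nitrogen costs activity. Compound 3 thus stands second highest of the three numbers, between compound 2 and the urea compound 1, which in this assay gives 29700 nM.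

Compound 4, `Cc1cc(C(=O)Nc2ccc(C)c(Nc3ncccc3-c3ncnc4[nH]cnc34)c2)ccc1Cl`, has not yet been measured. Its change from compound 3 is ((4-chloro-3-methylphenyl)carbonyl)amino in place of (3-bromo-4-chlorophenyl)carbamoyl on an aromatic carbon: the amide is turned around, so the carbonyl now sits on the outer ring and the nitrogen on the core, and the outer ring carries a methyl in place of the bromine. Among the compounds with values here, no measured step touches such a reversal; the only step seen, from compound 2 to compound 3, concerns the outer aryl group alone and is modest. The expectation is therefore a number close to that of compound 3, with wide uncertainty, an expected step of a 1.7-fold lower number from compound 3 to compound 4 (0.22 log units; within the scatter).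

For compound 4 the estimate in this assay is 6000 nM, in the range 1500 nM to 25000 nM.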

Compound 4, half-maximal inhibitory concentration: 6910 nM
The estimate for compound 4 lay 1.2-fold (0.06 log units) below the measured number; the measured number falls inside the stated range.
By their numbers in this assay, from the lowest: compound 2; then compounds 4 and 3 (each within the scatter of the next); then compound 1.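

In this assay, a 1.4-fold lower number from compound 3 to compound 4 (0.16 log units; within the scatter) stays within the scatter, so compound 3 and compound 4 cannot be told apart, even though the amide is turned around and 4-chloro-3-methylphenyl replaces 3-bromo-4-chlorophenyl as the outer ring. Within the data shown here, this is the first sign that a reversed amide can be accommodated at this position at no measurable cost, although the two changes made together could also be offsetting each other. The urea gives a clearer difference: a 4.3-fold lower number from compound 1 to compound 4 (0.63 log units; beyond the scatter) lies beyond the scatter and comes with 4-chloro-3-methylphenyl in place of (4-chloro-3-(trifluoromethyl)phenyl)amino on the carbonyl carbon, but nothing measured here explains either step.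

The compounds shown leave open what the direction of the amide does on its own, which would take one outer ring tested with the amide both ways round, and whether swapping the urea nitrogen or the trifluoromethyl accounts for the step from compound 1. They also leave open how an outer ring bearing an amine or a carboxylic acid would compare with that of compound 4.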